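From oxolan-3-yl to 4,4-difluorocyclohexyl on the shared core

The compounds below may be only part of what the source reports. "The series", "measured", "known", "first", "only" and "open" are said of these compounds alone.

In a physicochemical assay for solubility, using the shake flask method, in phosphate buffer, measured as kinetic solubility, with a stated time of 20 h, at pH 6.5 (a lower number here means a less soluble compound, a higher number a more soluble compound), compound 1 `FC(F)(F)Oc1ccc(-c2nc3cnc(Nc4ccccn4)cc3[nH]2)cc1` gives < 5000 nM as a limit of the assay, not a number. Compound 2 `FC(F)(F)c1cccc(-c2nc3cnc(Nc4ncccn4)cc3[nH]2)c1` likewise gives < 5000 nM as a limit. Compound 3 `FC(F)(F)c1ccc(Nc2cc3[nH]c(C4CCOC4)nc3cn2)nc1` with 166000 nM in this assay holds the only true number shown. Compound 4 `FC1(F)CCC(c2nc3cnc(Nc4ccc(C(F)(F)F)cn4)cc3[nH]2)CC1` carries 4,4-difluorocyclohexyl in place of oxolan-3-yl on an aromatic carbon. No measured step sizes this change, so compound 3 at 166000 nM serves as the sole starting point, and a clear drop is expected from there. In this assay the expected step is an 8.3-fold lower number from compound 3 to compound 4 (0.92 log units; beyond the scatter) and it should lie beyond the usual scatter. Compound 4 is expected near 20000 nM (estimated range 5000 nM to 80000 nM).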

Compound 4, solubility: 99000 nM
Compound 4: middle estimate off by 5.0-fold (0.69 log units), on the low side; measured number above the stated range.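

In this assay, the aromatic carbon between two ring nitrogen atoms now has its first measured step, for 4,4-difluorocyclohexyl in place of oxolan-3-yl: a 1.7-fold lower number from compound 3 to compound 4 (0.22 log units; within the scatter). The two values cannot be told apart, even though the ring oxygen leaves and two fluorine atoms enter. Neither value sits at the limit of the assay: the limit of < 5000 nM in this assay, at which 2 of the 4 values shown sit.

The compounds shown leave open what an amine or a carboxylic acid on this carbon would give. This single pair also cannot show whether the same exchange gives a similar step elsewhere.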